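The source may report more compounds than this note shows. Statements on the series, on what has been measured and on what is new or still open speak of the compounds shown alone.

Within the data shown here, compound 1 `COc1ccc(/C=N\NC(=S)NC(C)(C)CCC[C@](C)(O)[C@@H]2CC=C(C)CC2)cc1` gives 7660 nM in a functional assay on PCO3 cells (Homo sapiens) for cytotoxicity, read by sulforhodamine B assay (a lower number here means a stronger inhibitor of growth, a higher number a weaker inhibitor of growth), the second highest of the three numbers known so far. Compound 2 `CC1=CC[C@@H]([C@@](C)(O)CCCC(C)(C)NC(=S)N/N=C\c2ccc(O)cc2)CC1` gives 6230 nM, and compound 3 `CC1=CC[C@@H]([C@@](C)(O)CCCC(C)(C)NC(=S)N/N=C\c2ccc([N+](=O)[O-])cc2)CC1` gives 18100 nM. Among the measured compounds shown here, the step of a 1.2-fold lower number from compound 1 to compound 2 (0.09 log units; within the scatter) and the step of a 2.4-fold higher number from compound 1 to compound 3 (0.37 log units; beyond the scatter) are the only changes on the aromatic ring seen, and neither involves chlorine. Compound 4 `CC1=CC[C@@H]([C@@](C)(O)CCCC(C)(C)NC(=S)N/N=C\c2ccccc2Cl)CC1` differs from compound 1 in this way: 2-chlorophenyl in place of 4-methoxyphenyl on a carbon with a double bond to nitrogen. For the measured compounds named here, with no measured step covering chlorine on this ring, the closest guidance is the modest size of both known steps. A step within or just beyond the scatter is expected, a 1.2-fold higher number from compound 1 to compound 4 (0.07 log units; within the scatter), with no direction clearly favoured. For compound 4 the estimate is 9000 nM, expected to fall between 4000 nM and 20000 nM.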

Compound 4, concentration for 50% growth inhibition: 18800 nM
Compound 4: middle estimate off by 2.1-fold (0.32 log units), on the low side, within the range that was stated.
By their numbers in this assay, from the lowest: compounds 2 and 1 (each within the scatter of the next); then compounds 3 and 4 (each within the scatter of the next).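

In this assay, 2-chlorophenyl on the carbon with a double bond to nitrogen gives a 2.5-fold higher number from compound 1 to compound 4 (0.39 log units; beyond the scatter) and a 3.0-fold higher number from compound 2 to compound 4 (0.48 log units; beyond the scatter), so 4-methoxyphenyl and 4-hydroxyphenyl are both left behind by a modest margin. With a 1.0-fold higher number from compound 3 to compound 4 (0.02 log units; within the scatter), 2-chlorophenyl cannot be told apart from 4-nitrophenyl, so the weaker level is no longer seen with nitro alone. Nothing on hand explains these steps.

Each step changes both the substituent and its place on the ring, and these effects remain unseparated. Going by these compounds, how an amine or a carboxylic acid on the ring would compare remains open.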